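This account rests on a few compounds, and the source may have more. Where it says the series, first, only, none or still open, it means among the compounds named here.

Measured so far in a functional assay on MGC-803 cells (Homo sapiens) for inhibition, read by sulforhodamine B assay; on this read-out lower numbers stand for stronger inhibition and higher numbers for weaker inhibition:
compound 1, `O=C1C=C(Nc2cccc(F)c2)C(=O)c2c1nc1n2[C@H]2OC[C@@H](O)[C@H]2OC1`: 2180 nM
compound 2, `O=C1C=C(Nc2cccc(Cl)c2)C(=O)c2c1nc1n2[C@H]2OC[C@@H](O)[C@H]2OC1`: 1770 nM
compound 3, `O=C1C(Nc2cccc(Cl)c2)=CC(=O)c2c1nc1n2[C@H]2OC[C@@H](O)[C@H]2OC1`: 1530 nM

Compound 2 and compound 3 are built from the same atoms joined differently; the difference between the two cores is not broken down here. Compound 1 differs from compound 2 by fluoro in place of chloro on an aromatic carbon, and that step read a 1.2-fold higher number from compound 2 to compound 1 (0.09 log units; within the scatter). Compound 4, `O=C1C(Nc2cccc(F)c2)=CC(=O)c2c1nc1n2[C@H]2OC[C@@H](O)[C@H]2OC1`, is not yet measured in this assay; it differs from compound 3 by the same change, (fluoro in place of chloro on an aromatic carbon), placed on the core of compound 3. Resting on the earlier step of a 1.2-fold higher number from compound 2 to compound 1 (0.09 log units; within the scatter), a step of about the same size is expected for compound 4, namely a 1.2-fold higher number from compound 3 to compound 4 (0.08 log units; within the scatter). Compound 4 is therefore estimated at 1850 nM, with the expected range running from 900 nM to 3800 nM.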

Compound 4, half-maximal inhibitory concentration: 1470 nM
Estimate against measurement, compound 4: 1.3-fold (0.10 log units) above; low and high end bracket the measured number.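

On the core of compound 3, the change from 3-chlorophenyl to 3-fluorophenyl in this assay reads a 1.0-fold lower number from compound 3 to compound 4 (0.02 log units; within the scatter). Set beside the step on the other core, the change carries across the two cores with no difference that can be told apart: the same change on two cores in this assay, a 1.2-fold higher number (0.09 log units; within the scatter) from compound 2 to compound 1 and a 1.0-fold lower number (0.02 log units; within the scatter) from compound 3 to compound 4, 1.3-fold (0.11 log units) apart, within the scatter of two such steps. Both steps lie within the scatter, so this shows only that exchanging these two halogens leaves the number unmoved on both cores, and it does not show that a change with a larger step would carry the same way.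

Open, on these data alone, is whether a methoxy group, a nitrile, an amine or a carboxylic acid in place of the halogen would move the number on either core. Also open, as far as these compounds go, is whether any such step would match between the two cores.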